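Aryl amine swap on the shared core

The source may hold more compounds than are shown below. What is called first, only, known or untested is meant among the compounds shown, and "the series" means these compounds.

The series shares one core, seen in compound 1 `COC(=O)c1sc2cc(Nc3ccc(OC)cc3)cnc2c1N`, compound 2 `COC(=O)c1sc2cc(Nc3ccccc3Br)cnc2c1N`, compound 3 `COC(=O)c1sc2cc(Nc3ccc(F)cc3Br)cnc2c1N` and the unmeasured compound 4 `COC(=O)c1sc2cc(Nc3ccccn3)cnc2c1N`. In a functional assay on A375-C5 cells (Homo sapiens) for inhibition, read by sulforhodamine B assay, with a stated time of 48 h (on this read-out higher numbers stand for weaker inhibition of growth and lower numbers for stronger inhibition of growth), compound 2 gives 34100 nM, the highest of the two numbers; compound 3 gives 34000 nM, and the step of a 1.0-fold lower number from compound 2 to compound 3 (0.00 log units; within the scatter) stays within the scatter. Compound 1 gives only a limit, > 150000 nM, the limit (the limit of > 150000 nM in this assay, at which 1 of the 3 values shown sits). Compound 4 carries pyridin-2-yl in place of 2-bromophenyl on a nitrogen on an aromatic ring. Within the data shown here, no measured step touches this change; the one step recorded is a fluoro for hydrogen swap and says nothing about replacing the ring. Compound 1 sits at a limit. With compound 2 at 34100 nM, a weaker number is expected, with wide uncertainty. Compound 4 is therefore estimated at 60000 nM (range 15000 nM to 150000 nM), an expected step of a 1.8-fold higher number from compound 2 to compound 4 (0.25 log units; within the scatter).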

Compound 4, concentration for 50% growth inhibition: > 150000 nM
Compound 4: no number, only a limit (the forecaster's own chance of this, stated with the estimate: 35%); middle value at least 2.5-fold (0.39 log units) from the limit.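

In this assay, pyridin-2-yl in place of 2-bromophenyl on the nitrogen gives an at least 4.3-fold higher number from compound 2 to compound 4 (0.64 log units; beyond the scatter), so this position responds to a change of ring in a way the fluoro swap did not show. Compound 4 gives only a limit, not a number: the limit of > 150000 nM in this assay, at which 2 of the 4 values shown sit.

So far, numbers come only from the bromine-bearing rings of compound 2 and compound 3, while compound 1 and compound 4, without bromine, sit at the limit. Still open, as far as these compounds go, is whether losing the bromine or bringing in the ring nitrogen drives this step. A plain phenyl on the same nitrogen would separate the two.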